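The compounds below may be only part of what the source reports. "The series", "measured", "known", "first", "only" and "open" are said of these compounds alone.

Compound 1 `Cc1cc(NC(=O)Nc2ccccc2N)c2ccccc2n1` gives > 25000 nM in an ADME assay on Raji cells (Homo sapiens) for cytotoxicity, with a stated time of 72 h; a lower number here means that less compound is needed, a higher number that more compound is needed for the effect.
Compound 2 `Cc1ccc(NC(=O)Nc2cc(C)nc3ccccc23)cc1` gives > 25000 nM in this assay.
Compound 3 `Cc1cc(NC(=O)Nc2ncccc2C)c2ccccc2n1` gives > 25000 nM in this assay.

The value of compound 2 is a limit of this assay, not a measured number. The same holds for compound 1 and for compound 3, so all three values sit at the limit of > 25000 nM in this assay, at which 3 of the 3 values shown sit, and none of the steps among them can be read: a step that the two limits leave unreadable from compound 1 to compound 2, a step that the two limits leave unreadable from compound 1 to compound 3 and a step that the two limits leave unreadable from compound 2 to compound 3 are all left unreadable by the limits. Compound 2 therefore stands nowhere in particular within the set; it is simply at the limit together with the other two.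

The next compound, compound 4 `Cc1cc(NC(=O)Nc2ccc(C(=O)O)cc2)c2ccccc2n1`, differs from compound 2 at the aryl ring on the amide-type nitrogen: carboxy in place of methyl on an aromatic carbon. Within the data shown here, the measured steps that bear on it, from compound 1 and from compound 3 to compound 2, both exchange the whole group on that nitrogen without producing a readable number, so they give no direction and no size for the step in this assay.

With three limits and no readable step, compound 4 is expected to stay at the limit as well; the estimate is 40000 nM, within 15000 nM to 120000 nM. The expected step from compound 2 is a step that the limit leaves unreadable from compound 2 to compound 4, that is none beyond the scatter.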

Compound 4, half-maximal effective concentration: > 25000 nM
Compound 4 gave a limit, no number (the forecaster's own chance of this, stated with the estimate: 85%); the middle value is on the limit's open side.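

Compound 4 gives > 25000 nM in this assay as a limit and not a number. Compound 2 sits at the same limit, so no new step can be read between compound 2 and compound 4: the limit of > 25000 nM in this assay, at which 4 of the 4 values shown sit. The compounds shown leave open whether any change on the amide-type nitrogen moves the value in this assay at all.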